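Changing the group on a carbonyl carbon

This account rests on a few compounds, and the source may have more. Where it says the series, first, only, none or still open, it means among the compounds named here.

Compound 1 `CCCCCCCC/C=C\CCCCCCCC(=O)N1CCCC1`: 5.2 ug/mL
Compound 2 `CCCCCCCC/C=C\CCCCCCCC(=O)N1CCCCC1`: 10.6 ug/mL

In a functional assay on 786-0 cells (Homo sapiens) for antiproliferative activity, read by sulforhodamine B assay, with a stated time of 48 h (on this read-out lower numbers stand for stronger inhibition of growth and higher numbers for weaker inhibition of growth), compound 2 gives 10.6 ug/mL, the higher of the two numbers and so the weaker inhibition of growth. Within the data shown here, the only other measured value is that of compound 1, at 5.2 ug/mL. Compound 3 `CCCCCCCC/C=C\CCCCCCCC(=O)N1CCOCC1` differs from compound 2 in one place, on a carbonyl carbon: morpholin-4-yl in place of piperidin-1-yl on a carbonyl carbon.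

Among the measured compounds shown here, only one measured step bears on this change: a 2.0-fold higher number from compound 1 to compound 2 (0.31 log units; beyond the scatter). It is modest and involves the same carbonyl carbon, but it swaps a different pair of groups. It therefore suggests a size and gives no direction. A step no larger than that one is expected, in either direction, and it may well stay within the scatter. The estimated step is a 1.1-fold lower number from compound 2 to compound 3 (0.03 log units; within the scatter). For compound 3 the expected value in this assay is 10 ug/mL, with an estimated range of 4.5 ug/mL to 22 ug/mL.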

Compound 3, concentration for 50% growth inhibition: 4.5 ug/mL
Compound 3: middle estimate off by 2.2-fold (0.35 log units), on the high side, within the range that was stated.
By their numbers in this assay, from the lowest: compounds 3 and 1 (each within the scatter of the next); then compound 2.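

In this assay, ring size alone does not settle the outcome on this carbonyl carbon: morpholin-4-yl is also a six-membered non-aromatic ring, yet putting it in place of piperidin-1-yl gives a 2.4-fold lower number from compound 2 to compound 3 (0.37 log units; beyond the scatter). This step runs opposite to the earlier one, a 2.0-fold higher number from compound 1 to compound 2 (0.31 log units; beyond the scatter), so exchanging one ring carbon for oxygen reverses the earlier loss. Morpholin-4-yl in place of pyrrolidin-1-yl gives a 1.2-fold lower number from compound 1 to compound 3 (0.06 log units; within the scatter), so these two groups cannot be told apart here, and only compound 2, with piperidin-1-yl, stands apart as the weaker inhibitor of growth.

Nothing available explains why morpholin-4-yl and piperidin-1-yl differ. As far as these compounds go, it also remains open whether piperazin-1-yl, with a second ring nitrogen, or an open-chain diethylamino group on the same carbonyl carbon would match compound 2 or compound 3.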